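Swapping chloro for fluoro on a dianilino-nitrile core

A few compounds are considered here, and "the series" means these few. Any claim that something is new, unique, unknown or untested is made for them only; others in the source may bear on it.

The assay here is a functional assay on A549 cells (Homo sapiens) for cytotoxicity, read by MTT assay; a higher number here means a weaker inhibitor, a lower number a stronger inhibitor. Compound 1 (`N#Cc1c(Nc2ccccc2)c(Cl)c2nc(N)nc(N)c2c1F`) reaches only the limit of the assay, giving > 1000 ug/mL; that is a limit, not a number. Compound 2 (`N#Cc1c(Nc2ccc(Cl)cc2)c(F)c2nc(N)nc(N)c2c1F`) gives 115 ug/mL. Compound 3 (`CCCCNc1c(C#N)c(NCCCC)c2c(N)nc(N)nc2c1Cl`), which carries two butylamino groups instead of an anilino group, gives 2 ug/mL in this assay. Compound 3 thus holds the lowest of the two numbers; its nearest neighbour, compound 2, sits far above it, beyond the usual scatter. Compound 1 is only known through (the limit of > 1000 ug/mL in this assay, at which 1 of the 3 values shown sits).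

The next compound, compound 4 (`CCCCNc1c(C#N)c(NCCCC)c2c(N)nc(N)nc2c1F`), differs from compound 3 in one place only: fluoro in place of chloro on an aromatic carbon. Going by the values given here, no pair of measured compounds differs in just this way. Compounds 1 and 2 both carry a halogen at this place but also differ on their anilino groups, so they cannot show what the halogen alone does. With nothing to point in either direction, the expected step is a 1.5-fold higher number from compound 3 to compound 4 (0.18 log units; within the scatter), that is, no change beyond the scatter. Compound 4 is therefore estimated at 3 ug/mL in this assay. Compound 4 is expected to fall between 1 ug/mL and 10 ug/mL.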

Compound 4, half-maximal inhibitory concentration: > 1000 ug/mL
Compound 4 was reported as a limit; the forecaster's own chance of this, stated with the estimate: 0%; middle value at least 330-fold (2.52 log units) from the limit.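

In this assay, going by these compounds alone, the halogen at this place matters far more than the earlier compounds could show: fluoro in place of chloro gives an at least 500-fold higher number from compound 3 to compound 4 (2.69 log units; beyond the scatter). Within the data shown here, this is the first pair that isolates the halogen on the shared core, and it shows that exchanging one atom, with no ring, hydrogen-bond donor or hydrogen-bond acceptor entering or leaving, can take a compound with a measurable value in the low range of this set out of measurable range altogether. Compound 4 gives only a limit and not a number, so the step has a lower bound but no known full size, and the compound joins the set's other result at this ceiling: the limit of > 1000 ug/mL in this assay, at which 2 of the 4 values shown sit.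

The compounds shown leave open what other groups at this place, such as bromo, methyl or an amine, would do, so it remains unknown whether chloro is especially favourable or fluoro especially unfavourable. They also leave open whether the same halogen exchange would have so large an effect with a longer chain, such as hexylamino, in place of the two butylamino groups.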